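The compounds below may be only part of what the source reports. "The series", "measured", "known", "first", "only" and "open" are said of these compounds alone.

Compound 1 `COc1ccc2c(c1)OC(c1cc(OC)c(OC)c(OC)c1)C(C(=O)OCCc1ccccc1)=C2` in a functional assay for inhibition of nuclear factor NF-kappa-B complex (Homo sapiens) (a lower number here means a stronger inhibitor, a higher number a weaker inhibitor), gives 16200 nM. Compound 2 `COc1ccc2c(c1)OC(c1cc(OC)c(OC)c(OC)c1)C(C(=O)NC(C)C)=C2` reaches only a limit of the assay in this assay, namely > 50000 nM. Going by the values given here, the single measured step, an at least 3.0-fold higher number from compound 1 to compound 2 (0.48 log units; beyond the scatter), is therefore read against (the limit of > 50000 nM in this assay, at which 1 of the 2 values shown sits). Compound 3 `COc1ccc2c(c1)OC(c1cc(OC)c(OC)c(OC)c1)C(/C=N/O)=C2` differs from compound 2 by a group of 3 heavy atoms (1 carbon, 1 nitrogen, 1 oxygen; no ring) in place of a group of 6 heavy atoms (4 carbon, 1 nitrogen, 1 oxygen; no ring), on a double-bonded ring carbon. Among the compounds with values here, no measured step covers this particular change, and compound 2 sits at a limit, so the direction of the coming step is open. Compound 3 is expected to give 30000 nM, between 8000 nM and 150000 nM. The expected step of an at least 1.6-fold lower number from compound 2 to compound 3 (0.22 log units; that floor lies within the scatter) is counted from that limit.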

Compound 3, half-maximal inhibitory concentration: 14100 nM
The estimate for compound 3 lay 2.1-fold (0.33 log units) above the measured number; the measured number falls inside the stated range.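

In this assay, activity at this double-bonded ring carbon does not depend on keeping a carbonyl group: replacing isopropylcarbamoyl with a much smaller group without a carbonyl gives an at least 3.5-fold lower number from compound 2 to compound 3 (0.54 log units; beyond the scatter). Compared with the ester, the same small group gives a 1.1-fold lower number from compound 1 to compound 3 (0.06 log units; within the scatter), so a group with no ring performs on a par with the larger group that carries one. The first step has only a floor, as compound 2 stands at a limit of the assay: the limit of > 50000 nM in this assay, at which 1 of the 3 values shown sits.

As far as these compounds go, whether a carboxylic acid, an amine or a methyl ester at this carbon would give a lower number remains open.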